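Acetamido for Cyano on the Aniline of Compound 3

A few compounds are considered here, and "the series" means these few. Any claim that something is new, unique, unknown or untested is made for them only; others in the source may bear on it.

Compound 3 `CN(c1ncccc1CNc1nc(Nc2cccc(C#N)c2)nc2[nH]cc(F)c12)S(C)(=O)=O` stands apart from the other two measured compounds: in a functional assay on SMMC-7721 cells (Homo sapiens) for inhibition, read by MTT assay, with a stated time of 48 h (on this read-out lower numbers stand for stronger inhibition and higher numbers for weaker inhibition), compound 3 gives only a limit, > 100000 nM, and no number of its own. Compound 1 `Cc1c[nH]c2nc(Nc3ccc4c(c3)CC(=O)N4)nc(NCc3cccnc3N(C)S(C)(=O)=O)c12` gives 18700 nM in this assay. Compound 2 `CN(c1ncccc1CNc1nc(Nc2ccc3c(c2)CC(=O)N3)nc2[nH]cc(Cl)c12)S(C)(=O)=O` gives 21900 nM. Among the measured compounds shown here, the one measured step, a 1.2-fold higher number from compound 1 to compound 2 (0.07 log units; within the scatter), alters a substituent on the shared core, not the aniline side, so it does not bear directly on the change considered here and only shows that a small substituent swap left the read-out essentially unchanged.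

Compound 4 `CC(=O)Nc1cccc(Nc2nc(NCc3cccnc3N(C)S(C)(=O)=O)c3c(F)c[nH]c3n2)c1` differs from compound 3 by acetamido in place of cyano on an aromatic carbon. For the measured compounds named here, no measured step touches this part of the molecule, and compound 3 sits at the limit described by the limit of > 100000 nM in this assay, at which 1 of the 3 values shown sits, so the starting point itself is only bounded. Compound 4 is therefore expected to remain weak, with an estimated value of 70000 nM and a range from 20000 nM to 200000 nM. The step of an at least 1.4-fold lower number from compound 3 to compound 4 (0.15 log units; that floor lies within the scatter) is expected to stay close to the limit rather than move far from it.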

Compound 4, half-maximal inhibitory concentration: 16000 nM
Compound 4: the middle estimate sits 4.4-fold (0.64 log units) above what was measured, and the stated range ends above it.
By their numbers in this assay, from the lowest: compounds 4, 1 and 2 (each within the scatter of the next). At a limit, above all of these: compound 3.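

Among the compounds shown here, on the aniline side, which no earlier step touched, 3-cyanophenyl to 3-acetamidophenyl gives an at least 6.2-fold lower number from compound 3 to compound 4 (0.79 log units; beyond the scatter) in this assay. This position therefore responds to a change of group, and the change is the first shown to lie beyond the scatter, since the earlier step of chloro in place of methyl stayed within it. The printed size is only a floor, as compound 3 carries a limit and no number of its own: the limit of > 100000 nM in this assay, at which 1 of the 4 values shown sits.

As far as these compounds go, it remains open whether the amide hydrogen, the carbonyl or the acetamido group as a whole carries the step. Also open, from the compounds shown here alone, are how an amine, a carboxylic acid or a longer acyl chain would read at this place, and whether acetamido would give a similar step with chloro or methyl on the shared core.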